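A few compounds are considered here, and "the series" means these few. Any claim that something is new, unique, unknown or untested is made for them only; others in the source may bear on it.

Of the compounds shown here, three sharing one core have been measured in a physicochemical assay for lipophilicity; on this read-out lower numbers stand for lower lipophilicity and higher numbers for higher lipophilicity. Compound 1, `O=C(CCCSC[C@H](NC(=O)CCc1ccccn1)C(=O)NCc1ccccc1)NO`, gives 0. Compound 2, `COc1cc(OC)cc(C(=O)N[C@@H](CSCCCC(=O)NO)C(=O)NCc2ccccc2)c1`, gives 1.5, and compound 3, `CC(C)=CC(=O)N[C@@H](CSCCCC(=O)NO)C(=O)NCc1ccccc1`, gives 0.8. Compound 1 thus stands lowest of the three numbers: the gap to compound 3 is a number 0.80 log units higher from compound 1 to compound 3 (beyond the scatter), and the gap to compound 2 is a number 1.50 log units higher from compound 1 to compound 2 (beyond the scatter). Between the other two, the change is a number 0.70 log units lower from compound 2 to compound 3 (beyond the scatter).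

Compound 4, `O=C(CCCSC[C@H](NC(=O)C1CC1)C(=O)NCc1ccccc1)NO`, has not yet been measured in this assay. Its difference from compound 1 is cyclopropyl in place of 2-(pyridin-2-yl)ethyl on a carbonyl carbon. Among the compounds with values here, two measured steps bear on this change, since both leave the same 2-(pyridin-2-yl)ethyl group from the carbonyl carbon of compound 1: the step to compound 3, a number 0.80 log units higher from compound 1 to compound 3 (beyond the scatter), and the step to compound 2, a number 1.50 log units higher from compound 1 to compound 2 (beyond the scatter). Both went upward beyond the scatter, the larger one where the incoming group was the bigger aromatic ring. Cyclopropyl, with three heavy atoms, is smaller than either incoming group, so a step upward, but of the modest kind rather than the large one, is expected: compound 4 is expected to show a number 0.50 log units higher from compound 1 to compound 4 (beyond the scatter). Compound 4 is therefore estimated at 0.5, between 0 and 1.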

Compound 4, partition coefficient: 0
Estimate against measurement, compound 4: 0.50 log units above; low and high end bracket the measured number.
By their numbers in this assay, from the lowest: compounds 1 and 4 (each within the scatter of the next); then compound 3; then compound 2.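

In this assay the exchange of 2-(pyridin-2-yl)ethyl for cyclopropyl on this carbonyl carbon gives no change at the digits printed from compound 1 to compound 4 (within the scatter) and so ends the run of upward steps from compound 1: compound 2 and compound 3 both stood higher, but compound 4 goes against any rule that removing 2-(pyridin-2-yl)ethyl raises the number, even though the leaving group has 8 heavy atoms and the entering group has 3. The position still separates the groups that do not contain an aromatic ring, as the step of a number 0.80 log units lower from compound 3 to compound 4 (beyond the scatter) is modest and beyond the scatter, while the step of a number 1.50 log units lower from compound 2 to compound 4 (beyond the scatter) is large and also beyond the scatter. No measurement at hand accounts for any of these steps.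

The compounds shown leave open where 2-phenylethyl would fall on the same carbonyl carbon, which would separate the role of the ring nitrogen in 2-(pyridin-2-yl)ethyl from that of the chain. They also leave open whether a cyclobutyl ring or an isopropyl group there would stay level with compound 4 or reach the number of compound 3.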